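This account rests on a few compounds, and the source may have more. Where it says the series, first, only, none or still open, it means among the compounds named here.

Two compounds share one core and differ only in the group attached to a nitrogen on an aromatic ring. Compound 1 `Nc1ccccc1Nc1n[n+]([O-])c2ccccc2[n+]1[O-]` in a functional assay on HL-60 cells (Homo sapiens) for cytotoxicity, read by MTT assay, with a stated time of 48 h (on this read-out higher numbers stand for weaker inhibition and lower numbers for stronger inhibition), gives 8300 nM. Compound 2 `[O-][n+]1nc(NCCO)[n+]([O-])c2ccccc21` in this assay gives 10700 nM. Of these two numbers, compound 2 sits at one end and compound 1 at the other, yet the gap between them lies within the usual scatter of repeated measurements, so the two cannot be told apart.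

Compound 3 `[O-][n+]1nc(Nc2ccccc2)[n+]([O-])c2ccccc21` has not yet been measured. It differs from compound 2 in one place: phenyl in place of 2-hydroxyethyl on a nitrogen on an aromatic ring. Within the data shown here, no step between two measured compounds is known here, so the size of this change has to be inferred. Compound 1 also bears an aromatic ring on the same nitrogen and gives 8300 nM, a number close to that of compound 2. A step of about the scatter, leaning toward stronger inhibition, is therefore expected: a 1.5-fold lower number from compound 2 to compound 3 (0.18 log units; within the scatter). Compound 3 is expected to give 7000 nM in this assay, within a range from 2500 nM to 20000 nM.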

Compound 3, half-maximal inhibitory concentration: 2900 nM
Estimate against measurement, compound 3: 2.4-fold (0.38 log units) above; measured number inside the range.
By their numbers in this assay, from the lowest: compound 3; then compounds 1 and 2 (each within the scatter of the next).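

In this assay, the group on this nitrogen clearly matters: phenyl in place of 2-hydroxyethyl gives a 3.7-fold lower number from compound 2 to compound 3 (0.57 log units; beyond the scatter) and this step lies beyond the scatter. An aromatic ring on the nitrogen does not settle the number by itself, since hydrogen in place of amino on an aromatic carbon gives a 2.9-fold lower number from compound 1 to compound 3 (0.46 log units; beyond the scatter) and this step also lies beyond the scatter. Nothing available here explains why either change shifts the number.

From the compounds shown here alone, whether other groups on the phenyl ring, such as methoxy or chlorine, behave like amino or like hydrogen remains open. So does the question of where a plain ethyl chain or a benzyl group on the same nitrogen would fall relative to compound 2 and compound 3.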